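Bromine to chlorine on the pendant ring of a tetrabrominated core

The compounds below may be only part of what the source reports. "The series", "measured", "known", "first", "only" and "open" are said of these compounds alone.

In a functional assay on MCF7 cells (Homo sapiens) for antiproliferative activity, read by MTT assay, with a stated time of 48 h, tested at 12.5 uM (a lower number here means a stronger effect, a higher number a weaker effect of the compound at the concentration tested), compound 1 `OC(CCn1nc2c(Br)c(Br)c(Br)c(Br)c2n1)c1cccc(Br)c1` gives 102%. Within the data shown here, its one measured neighbour, compound 2 `OC(CCn1nc2c(Br)c(Br)c(Br)c(Br)c2n1)c1ccccc1`, gives 113%, so compound 1 holds the lowest of the two numbers in this assay, and the only counted step, a number 11 percentage points higher from compound 1 to compound 2 (beyond the scatter), comes from placing hydrogen in place of bromo on an aromatic carbon.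

Compound 3 `OC(CCn1nc2c(Br)c(Br)c(Br)c(Br)c2n1)c1ccc(Cl)cc1` differs from compound 1 by 4-chlorophenyl in place of 3-bromophenyl on a saturated chain carbon bound to an oxygen on a saturated carbon and a saturated chain carbon. Among the measured compounds shown here, no measured step in this set exchanges one halogenated phenyl for another, so the single step that bears on the change is the removal of the bromine in a number 11 percentage points higher from compound 1 to compound 2 (beyond the scatter), which raised the number modestly. Compound 3 keeps a halogen on that ring, so only part of that movement, if any, is expected to appear. For compound 3 the expected step in this assay is estimated as a number 4 percentage points higher from compound 1 to compound 3 (within the scatter), which lies within the scatter.

Compound 3 is therefore estimated at 106% in this assay, with a range from 92% to 120%.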

Compound 3, a percentage reported as activity, at one concentration (the size of the read-out at that concentration, not a potency): 100%
Estimate against measurement, compound 3: 6 percentage points above; the measured number falls inside the stated range.
By their numbers in this assay, from the lowest: compounds 3 and 1 (each within the scatter of the next); then compound 2.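

In this assay, the exchange of 3-bromophenyl for 4-chlorophenyl gives a number 2 percentage points lower from compound 1 to compound 3 (within the scatter), so at this position on the saturated chain carbon the two halogenated phenyl groups cannot be told apart. The second new step, with chloro in place of hydrogen on an aromatic carbon, gives a number 13 percentage points lower from compound 2 to compound 3 (beyond the scatter); this is a second case, alongside the bromo pair, in which the compound without a halogen on this ring, compound 2, holds the higher number, and it goes against no compound shown. Nothing available explains why a halogen on this ring goes with the lower number.

The step from compound 1 to compound 3 changes both the halogen and its ring position at once, so the compounds shown cannot separate the contribution of either, and a single halogenated pair cannot show whether the two effects cancel. On these data alone, it also remains open how this ring position responds to a group other than a halogen, such as an amine or a carboxylic acid, and whether any change here could bring the number in this assay far below that of compound 3, at 100%.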